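Benzoyloxy in Place of 2,5-Dioxopyrrolidin-1-yl: Compound 4

A few compounds are considered here, and "the series" means these few. Any claim that something is new, unique, unknown or untested is made for them only; others in the source may bear on it.

Measured compounds:
Compound 1 `COC(=O)CC1CCN(C[C@H]2CN(c3ccc(-n4cc(-c5ccccn5)cn4)c(F)c3)C(=O)O2)CC1` gives 1.78.
Compound 2 `O=C1O[C@@H](CN2CCC(O)CC2)CN1c1ccc(-n2cc(-c3ccccn3)cn2)c(F)c1` gives 1.63.
Compound 3 `O=C1CCC(=O)N1C[C@H]1CN(c2ccc(-n3cc(-c4ccccn4)cn3)c(F)c2)C(=O)O1` gives 1.58.

Of the compounds shown here, three sharing one core have been read in a physicochemical assay for lipophilicity, read by HPLC, measured as octanol-water partition; a lower number here means a more polar compound, a higher number a more lipophilic compound. Compound 3 holds the lowest of the three numbers, yet both of its neighbours sit within the scatter of it: a number 0.05 log units lower from compound 2 to compound 3 (within the scatter), and a number 0.20 log units lower from compound 1 to compound 3 (within the scatter). The remaining pair also stays within the scatter: a number 0.15 log units lower from compound 1 to compound 2 (within the scatter). On the numbers shown, the three measured compounds cannot be told apart.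

Compound 4 `O=C(OC[C@H]1CN(c2ccc(-n3cc(-c4ccccn4)cn3)c(F)c2)C(=O)O1)c1ccccc1` differs from compound 3 in one place: benzoyloxy in place of 2,5-dioxopyrrolidin-1-yl on a saturated chain carbon bound to a saturated ring carbon. All three measured steps exchange one substituent for another at this same place, and each of them is within the scatter. For the measured compounds named here, none of them, however, brings in a six-membered aromatic ring of carbon only, nor removes a five-membered non-aromatic ring with one hetero atom, so they offer no direct precedent for the step to compound 4; they only show that the core tolerates changes here without large movement of the read-out.

With that gap in precedent, the estimate for compound 4 rests on the entering benzoyloxy group itself and is expected at 2.8, within the range 2.1 to 3.5, which would mean an expected step of a number 1.22 log units higher from compound 3 to compound 4 (beyond the scatter).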

Compound 4, partition coefficient: 4.21
Beside the measured number, compound 4's estimate is 1.41 log units below it, outside the stated range (above it).
By their numbers in this assay, from the lowest: compounds 3, 2 and 1 (each within the scatter of the next); then compound 4.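

The earlier exchanges at this place, on a saturated chain carbon bound to a saturated ring carbon, stayed within the scatter and could have suggested that the read-out of this assay barely responds to what sits there, but compound 4 shows otherwise: benzoyloxy separates it clearly from all three other compounds (a number 2.63 log units higher from compound 3 to compound 4 (beyond the scatter); a number 2.58 log units higher from compound 2 to compound 4 (beyond the scatter); a number 2.43 log units higher from compound 1 to compound 4 (beyond the scatter)). These three steps are large and close to one another, so compound 4 stands apart from a group of compounds that cannot be told apart, whichever of the three departing groups is taken as the starting point. The compounds shown offer no measured explanation for this separation.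

For the compounds shown here, compound 4 alone carries benzoyloxy, so its one exchange brings in the six-membered aromatic ring of carbon only together with the oxygen-linked carbonyl, and the share of each in the step remains open. An acetoxy group at this place would keep the link without the aromatic ring, while a benzylamino group would keep the aromatic ring on a different link, and either could begin to separate the two.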